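A few compounds are considered here, and "the series" means these few. Any claim that something is new, unique, unknown or untested is made for them only; others in the source may bear on it.

Compound 1 `CC(C)(C)c1cc(NC(=O)Nc2ccc(-c3cn4cc(Cl)ccc4n3)cc2)no1` gives 24.8 nM in a functional assay on MV4-11 cells (Homo sapiens) for cytotoxicity, read by MTT assay, with a stated time of 72 h; a lower number here means a stronger inhibitor, a higher number a weaker inhibitor. Going by the values given here, compound 2 `Cc1ccc2nc(-c3ccc(NC(=O)Nc4cc(C(C)(C)C)on4)cc3)cn2c1` gives 4.08 nM in this assay, the lowest of the two numbers measured so far; the step of a 6.1-fold lower number from compound 1 to compound 2 (0.78 log units; beyond the scatter) is the only measured step, and it alters the substituent on the same aromatic carbon that is varied next. Compound 3 `C#Cc1ccc2nc(-c3ccc(NC(=O)Nc4cc(C(C)(C)C)on4)cc3)cn2c1` differs from compound 2 by ethynyl in place of methyl on an aromatic carbon. Among the compounds with values here, no measured compound carries an ethynyl group at this place, so the chloro-to-methyl step is only an indirect guide: it shows that exchanging the substituent on this carbon moved the number by a modest amount, but it does not tell whether ethynyl will move it as methyl did. The step of a 1.2-fold higher number from compound 2 to compound 3 (0.09 log units; within the scatter) in this assay is therefore expected to be small, quite possibly within the scatter. Compound 3 is estimated at 5 nM in this assay, with a range from 1.5 nM to 18 nM.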

Compound 3, half-maximal inhibitory concentration: 8.62 nM
The estimate for compound 3 lay 1.7-fold (0.24 log units) below the measured number, and the stated range covers the measured number.
By their numbers in this assay, from the lowest: compound 2; then compound 3; then compound 1.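

Ethynyl is the first group on this aromatic carbon with a triple bond and more than one heavy atom, and in this assay it is accepted without a large loss: the move gives a 2.1-fold higher number from compound 2 to compound 3 (0.32 log units; beyond the scatter), a modest rise that lies beyond the scatter. It also keeps an advantage over the chloro group, with a 2.9-fold lower number from compound 1 to compound 3 (0.46 log units; beyond the scatter), so the three groups now form an order in which ethynyl falls between methyl and chloro and methyl still gives the lowest number. Nothing shown here explains this order.

The compounds shown leave open whether an amine, a methoxy group or a longer alkyl chain on this carbon would fall inside this narrow band or outside it. They also leave open whether the same order would hold with any other change to the shared core.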